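The compounds below may be only part of what the source reports. "The series", "measured", "known", "first", "only" and "open" are said of these compounds alone.

Compound 1, `CN(C)CCCCn1c(N)c(-c2nc3ccccc3n2C)c2nc(C#N)c(C#N)nc21`, opens this account. In an ADME assay on HEK293 cells (Homo sapiens) for cytotoxicity, read by MTT assay, with a stated time of 48 h (on this read-out higher numbers stand for weaker inhibition and lower numbers for stronger inhibition), compound 1 gives 3870 nM. Compound 2, `CCN(CC)CCCCn1c(N)c(-c2nc3ccccc3n2C)c2nc(C#N)c(C#N)nc21`, differs from compound 1 by diethylamino in place of dimethylamino on a saturated chain carbon, four bonds along the chain from an aromatic nitrogen. That change brought a 1.2-fold lower number from compound 1 to compound 2 (0.09 log units; within the scatter), and in this assay compound 2 gives 3160 nM. Compound 3, `CN(C)CCCn1c(N)c(-c2nc3cc(Cl)ccc3[nH]2)c2nc(C#N)c(C#N)nc21`, is built on a different core; the difference between the two cores is not broken down here. In this assay compound 3 gives 11700 nM, the highest of the three numbers, standing beyond the scatter from both compound 1 and compound 2. Compound 4, `CCN(CC)CCCn1c(N)c(-c2nc3cc(Cl)ccc3[nH]2)c2nc(C#N)c(C#N)nc21`, has not yet been measured and differs from compound 3 by diethylamino in place of dimethylamino on a saturated chain carbon, three bonds along the chain from an aromatic nitrogen. Among the measured compounds shown here, this is the same kind of change as the one from compound 1 to compound 2, though not the same: there the saturated chain carbon lies four bonds along the chain from an aromatic nitrogen, here three bonds along the chain from an aromatic nitrogen. Because the earlier change produced only a 1.2-fold lower number from compound 1 to compound 2 (0.09 log units; within the scatter), a similarly small step is expected here: a 1.2-fold lower number from compound 3 to compound 4 (0.07 log units; within the scatter). Compound 4 is accordingly estimated at 10000 nM, with a likely range from 5000 nM to 22000 nM.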

Compound 4, half-maximal inhibitory concentration: 8420 nM
The estimate for compound 4 lay 1.2-fold (0.07 log units) above the measured number; low and high end bracket the measured number.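

In this assay, diethylamino in place of dimethylamino gives a 1.4-fold lower number from compound 3 to compound 4 (0.14 log units; within the scatter), and this step matches the earlier one on the other core: the same change on two cores in this assay, a 1.2-fold lower number (0.09 log units; within the scatter) from compound 1 to compound 2 and a 1.4-fold lower number (0.14 log units; within the scatter) from compound 3 to compound 4, 1.1-fold (0.05 log units) apart, within the scatter of two such steps Across these two pairs, then, the change carries over as a small step that stays within the scatter, both on a saturated chain carbon four bonds along the chain from an aromatic nitrogen and on one three bonds along. This does not show that the change would stay as small on any other core, and the two pairs differ in both core and chain, so the part played by each cannot be separated here.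

The compounds shown leave open whether a different amine, such as dipropylamino or a primary amine, would also stay within the scatter of these numbers. They also leave open how either amine would read on a longer chain, or with both cores carrying the same chain.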